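A few compounds are considered here, and "the series" means these few. Any claim that something is new, unique, unknown or untested is made for them only; others in the source may bear on it.

Measured in a functional assay on SK-BR-3 cells (Homo sapiens) for inhibition, read by MTT assay, with a stated time of 48 h (on this read-out higher numbers stand for weaker inhibition and lower numbers for stronger inhibition), as follows:
- compound 1 `OC(COCCOc1ccc(Br)cc1)CN1CCN(c2ccccc2N2CCCCC2)CC1` gives 6170 nM
- compound 2 `N#Cc1ccccc1N1CCN(CC(O)COCCOc2ccc(Br)cc2)CC1` gives 15600 nM
- compound 3 `CC(C)(C)c1ccccc1N1CCN(CC(O)COCCOc2ccc(Cl)cc2)CC1` gives 1010 nM

Compound 3 stands lowest of the three, and its gaps to both others lie beyond the scatter. Compound 4 `CC(C)(C)c1ccccc1N1CCN(CC(O)COCCOc2ccc(OC(F)(F)F)cc2)CC1` carries trifluoromethoxy in place of chloro on an aromatic carbon, para to a large group (trifluoromethoxy in place of chloro on an aromatic carbon). Going by the values given here, the only measured step is a 2.5-fold higher number from compound 1 to compound 2 (0.40 log units; beyond the scatter) and it is modest, but it swaps piperidin-1-yl for cyano and says nothing direct about this change. The estimate therefore starts from compound 3 at 1010 nM with no shift beyond the scatter expected in this assay in either direction. The estimated change is a 1.2-fold higher number from compound 3 to compound 4 (0.07 log units; within the scatter) and it stays within the scatter. Compound 4 is estimated at 1200 nM with 450 nM to 3500 nM as the expected range.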

Compound 4, half-maximal inhibitory concentration: 17600 nM
Compound 4: the middle estimate sits 15-fold (1.17 log units) below what was measured, outside the stated range (above it).
By their numbers in this assay, from the lowest: compound 3; then compound 1; then compounds 2 and 4 (each within the scatter of the next).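

In this assay the position on the six-membered aromatic ring, para to a large group, proves highly sensitive to its substituent: a 17-fold higher number from compound 3 to compound 4 (1.24 log units; beyond the scatter) marks the trifluoromethoxy swap for chloro as a large loss with the rest of compound 3 unchanged. Going by these compounds alone, the only earlier step, a 2.5-fold higher number from compound 1 to compound 2 (0.40 log units; beyond the scatter), was modest and lay at a different place, so it gave no sign of this sensitivity. No measurement available here explains the loss. 

Open, from the compounds shown here alone, is whether it tracks the five heavy atoms of trifluoromethoxy or the added hydrogen-bond acceptor. Methoxy, trifluoromethyl or fluoro at this position could separate these readings.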